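This account rests on a few compounds, and the source may have more. Where it says the series, first, only, none or still open, it means among the compounds named here.

Measured so far in an assay on isolated protein for inhibition of P-selectin glycoprotein ligand 1 (Homo sapiens), read by surface plasmon resonance, tested at 250 uM; on this read-out lower numbers stand for less inhibition and higher numbers for more inhibition at the one concentration tested (going by the name of the read-out):

Compound 1 `CC(c1ccccc1)c1nc2c(C(F)(F)F)cccc2c(C(=O)O)c1O` gives 50%.
Compound 2 `CCC(c1ccccc1)c1nc2c(C(F)(F)F)cccc2c(C(=O)O)c1O` gives 55%.
Compound 3 `Cc1cc(C(F)(F)F)c2nc(C3(c4ccc(Cl)cc4)CC3)c(O)c(C(=O)O)c2c1` gives 65%.

Compound 2 differs from compound 1 only by methyl in place of hydrogen on a saturated chain carbon, two bonds along the chain from two aromatic carbons, and this change made the step of a number 5 percentage points higher from compound 1 to compound 2 (within the scatter). Compound 3 sits on a different core; the difference between the two cores is not broken down here, so only its value stands beside the others.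

Compound 4 `CCc1cc(C(F)(F)F)c2nc(C3(c4ccc(Cl)cc4)CC3)c(O)c(C(=O)O)c2c1` has not yet been measured. It differs from compound 3 by methyl in place of hydrogen on a saturated chain carbon bound to an aromatic carbon. Among the compounds with values here, this is the same kind of change as the one from compound 1 to compound 2, but not the same: there the place was on a saturated chain carbon, two bonds along the chain from two aromatic carbons, whereas here it is on a saturated chain carbon bound to an aromatic carbon. Resting on the step of a number 5 percentage points higher from compound 1 to compound 2 (within the scatter), a step of about a number 3 percentage points higher from compound 3 to compound 4 (within the scatter) is expected from compound 3 to compound 4. Compound 4 is therefore estimated at 68%, most likely within 55% to 80%.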

Compound 4, a percentage reported as inhibition, at one concentration (the size of the read-out at that concentration, not a potency): <= 10%
Compound 4: only a limit was reported; the forecaster's own chance of this, stated with the estimate: 5%; at least 58 percentage points between middle value and limit.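

Methyl in place of hydrogen gave a step of a number at least 55 percentage points lower from compound 3 to compound 4 (beyond the scatter) in this assay, so this change did not carry over from one core to the other with a similar result. For compound 4, the reported <= 10% is a limit of the assay, not a number. The two steps clearly differ, but the change also sits at a different place on each core, so the data do not show whether the core or the place accounts for the gap: the same change on two cores in this assay, a number 5 percentage points higher (within the scatter) from compound 1 to compound 2 and a number at least 55 percentage points lower (beyond the scatter) from compound 3 to compound 4, at least 60 percentage points apart, beyond the scatter of two such steps.

The compounds shown leave open how a longer chain than ethyl, an amine or a methoxy group would behave at this place on the core of compound 3. They also leave open whether the chain carbon bound to an aromatic carbon in the core of compound 1 would respond in the same way.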